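This account rests on a few compounds, and the source may have more. Where it says the series, first, only, none or still open, it means among the compounds named here.

Compound 1 `COc1ccc(-n2cc(COc3c(/C=C\C(=O)O)ccc(OC)c3CC=C(C)C)nn2)cc1` has in a functional assay on A-431 cells (Homo sapiens) for cytotoxicity, read by MTT assay, with a stated time of 24 h (a higher number here means a weaker inhibitor, a lower number a stronger inhibitor), the result "not determined" (no result reported); its place on this scale is simply unknown. Two related compounds have been measured. In this assay compound 2 `COc1ccccc1-n1cc(COc2c(/C=C\C(=O)O)ccc(OC)c2CC=C(C)C)nn1` gives 32600 nM, and compound 3 `COc1ccc(/C=C\C(=O)O)c(OCc2cn(-c3ccccc3C#N)nn2)c1CC=C(C)C` gives 10300 nM, and a 3.2-fold lower number from compound 2 to compound 3 (0.50 log units; beyond the scatter). Compound 4 `COc1ccc(/C=C\C(=O)O)c(OCc2cn(-c3ccc(NC(=O)c4ccccc4)cc3)nn2)c1CC=C(C)C` differs from compound 1 by benzamido in place of methoxy on an aromatic carbon. Among the measured compounds shown here, that change has no measured counterpart here: the only recorded step exchanges methoxy for cyano on a different carbon, so it gives a sense of the scale but not of this direction. Both measured values are weak, and compound 4 is expected to remain in the same weak region, with an estimated value of 15000 nM, plausibly between 3000 nM and 60000 nM.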

Compound 4, half-maximal inhibitory concentration: 21200 nM
Compound 4: middle estimate off by 1.4-fold (0.15 log units), on the low side; the measured number falls inside the stated range.
By their numbers in this assay, from the lowest: compound 3; then compounds 4 and 2 (each within the scatter of the next).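

In this assay, among the compounds shown here, compound 1 gives "not determined" (no result reported), so no step to compound 4 can be read. From the compounds shown here alone, the effect of benzamido in place of methoxy stays open, and no other data here bear on this result.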